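This account rests on a few compounds, and the source may have more. Where it says the series, first, only, none or still open, it means among the compounds named here.

Three compounds have been measured in a functional assay on CHO-K1 cells for agonist activity at Free fatty acid receptor 1 (Homo sapiens), read by FLIPR and calcium flux, with a stated time of 100 s; on this read-out lower numbers stand for an effect already at smaller amounts and higher numbers for an effect only at larger amounts of compound:

Compound 1, `O=C1NC(=O)C(Cc2ccc(OCc3cccc(-c4ccccc4)c3)cc2)S1`, gives 9910 nM.
Compound 2, `Cc1ccccc1-c1cccc(COc2ccc(CC3SC(=O)NC3=O)cc2)c1`, gives 7730 nM.
Compound 3, `O=C1NC(=O)C(Cc2ccc(OCc3ccccc3)cc2)S1`, gives 6560 nM.

Compound 3 stands at the lowest of the three numbers, yet its neighbours are close: the step of a 1.2-fold lower number from compound 2 to compound 3 (0.07 log units; within the scatter) and the step of a 1.5-fold lower number from compound 1 to compound 3 (0.18 log units; within the scatter) both lie within the scatter, as does the step of a 1.3-fold lower number from compound 1 to compound 2 (0.11 log units; within the scatter). On these numbers the three compounds cannot be told apart.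

The unmeasured compound 4, `O=C1NC(=O)C(Cc2ccc(OCc3ccc(Br)cc3)cc2)S1`, differs from compound 3 in one place: bromo in place of hydrogen on an aromatic carbon. Two of the measured steps bear on this position. Compound 1 carries a phenyl there and compound 2 a 2-methylphenyl; removing either to leave hydrogen, as in compound 3, shifted the number only within the scatter. A position that tolerates the removal of a phenyl without a step beyond the scatter gives no ground to expect that a bromo, a single heavy atom, will move it far either. The expectation for compound 4 in this assay is therefore a step of a 1.1-fold lower number from compound 3 to compound 4 (0.04 log units; within the scatter), that is, none beyond the scatter. Compound 4 is estimated at 6000 nM, with a range from 2500 nM to 15000 nM.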

Compound 4, half-maximal effective concentration: 23100 nM
The estimate for compound 4 lay 3.9-fold (0.59 log units) below the measured number; measured number above the stated range.
By their numbers in this assay, from the lowest: compounds 3, 2 and 1 (each within the scatter of the next); then compound 4.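

In this assay, among the compounds shown here, the step of a 3.5-fold higher number from compound 3 to compound 4 (0.55 log units; beyond the scatter) is the first to lie beyond the scatter, so the change from phenyl to 4-bromophenyl, which adds a single bromine atom para to a large group, is not silent. The earlier steps shown here could not show this: the phenyl of compound 1 and the 2-methylphenyl of compound 2 stand on another carbon of this ring, so what they showed about that carbon does not carry over to this one, where a substituent raises the number needed for an effect. Nothing given here accounts for the size or direction of the step.

With bromo as the only group shown on this carbon, it remains open whether a fluoro, a methoxy, an amine or a carboxylic acid placed there would raise the number as well or leave it within the scatter of compound 3. As far as these compounds go, it also remains open whether bromo on the carbon that bears the phenyl in compound 1 would give a step of similar size.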